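The source may report more compounds than this note shows. Statements on the series, on what has been measured and on what is new or still open speak of the compounds shown alone.

Measured compounds:
compound 1, `O=C(Nc1ccc(Oc2ccnc3[nH]ccc23)cc1)c1cn(-c2ccc(F)c(Cl)c2)c2ccccc2c1=O`, 4810 nM;
compound 2, `COc1ccc(-n2cc(C(=O)Nc3ccc(Oc4ccnc5[nH]ccc45)cc3)c(=O)c3ccccc32)cc1`, 4980 nM;
compound 3, `Cn1ccc2c(Oc3ccc(NC(=O)c4cn(-c5ccc(F)c(Cl)c5)c5ccccc5c4=O)cc3F)ccnc21`, 1210 nM.

In a functional assay on A549 cells (Homo sapiens) for inhibition, read by MTT assay, with a stated time of 72 h (a lower number here means a stronger inhibitor, a higher number a weaker inhibitor), compound 1 gives 4810 nM. Compound 2 carries 4-methoxyphenyl in place of 3-chloro-4-fluorophenyl on an aromatic nitrogen and in this assay gives 4980 nM, a step of a 1.0-fold higher number from compound 1 to compound 2 (0.02 log units; within the scatter). Compound 3 differs from compound 1 in its core in a way that is not broken down here; in this assay compound 3 gives 1210 nM, the lowest of the three numbers, with both other compounds beyond the scatter from it, so compound 3 is the strongest inhibitor of the three.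

Compound 4 `COc1ccc(-n2cc(C(=O)Nc3ccc(Oc4ccnc5c4ccn5C)c(F)c3)c(=O)c3ccccc32)cc1` is not yet measured. It stands to compound 3 as compound 2 stands to compound 1: 4-methoxyphenyl in place of 3-chloro-4-fluorophenyl on an aromatic nitrogen, the same change at the same place. Compound 4 is therefore expected to sit close to compound 3, with an estimated step of a 1.1-fold higher number from compound 3 to compound 4 (0.03 log units; within the scatter), because the same change earlier gave a 1.0-fold higher number from compound 1 to compound 2 (0.02 log units; within the scatter). For compound 4 the estimate in this assay is 1300 nM, expected to fall between 600 nM and 3000 nM.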

Compound 4, half-maximal inhibitory concentration: 3210 nM
Compound 4: middle estimate off by 2.5-fold (0.39 log units), on the low side; the measured number lies above the stated range.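

In this assay, putting 4-methoxyphenyl in place of 3-chloro-4-fluorophenyl on the aromatic nitrogen gives a 2.7-fold higher number from compound 3 to compound 4 (0.42 log units; beyond the scatter). Set beside the earlier step on the core of compound 1, this step cannot be told apart from it: the same change on two cores in this assay, a 1.0-fold higher number (0.02 log units; within the scatter) from compound 1 to compound 2 and a 2.7-fold higher number (0.42 log units; beyond the scatter) from compound 3 to compound 4, 2.6-fold (0.41 log units) apart, within the scatter of two such steps. The two pairs therefore do not show that the core alters what this change does, yet with one step within the scatter and the other beyond it, they do not establish that the change carries over unaltered either.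

As far as these compounds go, it remains open how an amine or a carboxylic acid in place of the methoxy group would read in this assay. Also open, from the compounds shown here alone, is which part of the difference between the cores of compound 1 and compound 3 bears on the size of the step.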